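A few compounds are considered here, and "the series" means these few. Any claim that something is new, unique, unknown or untested is made for them only; others in the source may bear on it.

Measured so far in a functional assay on SK-BR-3 cells (Homo sapiens) for antiproliferative activity; a lower number here means a stronger inhibitor, a higher number a weaker inhibitor:

Compound 1 `CC(=O)Oc1ccc(C(=O)Nc2cc3ccc(OCCC4CCCCN4)c(C)c3oc2=O)cc1CC=C(C)C`: 640 nM
Compound 2 `CCCNCCCOc1ccc2cc(NC(=O)c3ccc(O)c(CC=C(C)C)c3)c(=O)oc2c1C`: 990 nM
Compound 3 `CC(C)=CCc1cc(C(=O)Nc2cc3ccc(OCCCN(C(C)C)C(C)C)c(C)c3oc2=O)ccc1O`: 1600 nM

Compound 3 has the highest of the three numbers in this assay, but its gap to compound 2 is within the scatter; only compound 1 sits clearly lower.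

Compound 4 `CC(C)=CCc1cc(C(=O)Nc2cc3ccc(OCCCN[C@@H]4C[C@H]5CC[C@@H]4C5)c(C)c3oc2=O)ccc1O` differs from compound 3 as follows: a group of 8 heavy atoms (7 carbon, 1 nitrogen; 2 five-membered non-aromatic rings of carbon only) in place of a group of 7 heavy atoms (6 carbon, 1 nitrogen; no ring), on a saturated chain carbon, three bonds along the chain from an oxygen on an aromatic ring. Among the measured compounds shown here, the one step bearing on this change at the same chain carbon is a 1.6-fold higher number from compound 2 to compound 3 (0.21 log units; within the scatter), within the scatter. For the measured compounds named here, compound 1 alters a different part of the chain and supplies no step to compound 3. Amine changes at this position have so far moved the number little, so no step beyond the scatter is expected; compound 4 is estimated at 1100 nM (range 450 nM to 2700 nM), a change of a 1.5-fold lower number from compound 3 to compound 4 (0.16 log units; within the scatter).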

Compound 4, half-maximal inhibitory concentration: 770 nM
Beside the measured number, compound 4's estimate is 1.4-fold (0.15 log units) above it; the range from low to high includes it.
By their numbers in this assay, from the lowest: compounds 1, 4, 2 and 3 (each within the scatter of the next, the first and the last beyond it).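

In this assay, among the compounds shown here, the amine with 2 five-membered non-aromatic rings of carbon only, in place of diisopropylamino, gives a 2.1-fold lower number from compound 3 to compound 4 (0.32 log units; beyond the scatter) and so is the one step at this chain carbon that lies beyond the scatter. Measured against propylamino on the amine nitrogen, the same ring group gives a 1.3-fold lower number from compound 2 to compound 4 (0.11 log units; within the scatter) and so separates only from diisopropylamino. No supporting data explain this difference.

As far as these compounds go, whether a morpholine or a cyclohexylamino group at this chain carbon would match compound 4 remains open. Also open, from the compounds shown here alone, is whether the mirror-image form of its amine would give a similar number.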